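The compounds below may be only part of what the source reports. "The series", "measured", "known", "first", "only" and "open" are said of these compounds alone.

Measured in a functional assay on MCF7 cells (Homo sapiens) for antiproliferative activity, read by MTT assay; on this read-out lower numbers stand for stronger inhibition and higher numbers for weaker inhibition:

- compound 1 `NS(=O)(=O)c1ccc(C(=O)N/N=C(/CS(=O)(=O)c2ccccc2)c2ccc(Cl)cc2)cc1`: 57000 nM
- compound 2 `C/C(=N/NC(=O)c1ccc(S(N)(=O)=O)cc1)c1ccccc1`: 20100 nM
- compound 3 `C/C(=N/NC(=O)c1ccc(S(N)(=O)=O)cc1)c1ccc(Br)cc1`: 2290 nM

Of these three, compound 3 gives the lowest number, 2290 nM. The next structure, compound 4 `C/C(=N/NC(=O)c1ccc(S(N)(=O)=O)cc1)c1ccc(Cl)cc1`, has chloro in place of bromo on an aromatic carbon. Within the data shown here, no measured step exchanges these two groups directly. Among the measured compounds shown here, the only single-place step that bears on the change is an 8.8-fold lower number from compound 2 to compound 3 (0.94 log units; beyond the scatter), with bromo in place of hydrogen on an aromatic carbon. That step is modest but lies beyond the scatter. Compound 4 keeps a group at the same place, so in this assay it is expected to stay much nearer to compound 3 than to compound 2, at 20100 nM. A small move towards a higher number is expected, possibly no more than the scatter. The expected change is a 1.5-fold higher number from compound 3 to compound 4 (0.18 log units; within the scatter). Compound 4 is estimated at 3500 nM, with an expected range of 1400 nM to 10000 nM.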

Compound 4, half-maximal inhibitory concentration: 3750 nM
Compound 4: the middle estimate sits 1.1-fold (0.03 log units) below what was measured; the range from low to high includes it.
By their numbers in this assay, from the lowest: compounds 3 and 4 (each within the scatter of the next); then compound 2; then compound 1.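

In this assay the change from 4-bromophenyl to 4-chlorophenyl gives a 1.6-fold higher number from compound 3 to compound 4 (0.21 log units; within the scatter) and so does not separate the two halogens at this place, on an aromatic carbon para to a large group. Chloro also stands against hydrogen here, with a 5.4-fold lower number from compound 2 to compound 4 (0.73 log units; beyond the scatter), so among the compounds shown the drop from hydrogen is not tied to bromo alone. With the 4-chlorophenyl held, a 15-fold lower number from compound 1 to compound 4 (1.18 log units; beyond the scatter) adds a second place to the picture, where hydrogen replaces phenylsulfonyl on the saturated chain carbon.

On these data alone, whether fluoro, methoxy or an amine at the halogen's place would stay with chloro and bromo or fall back towards hydrogen remains open, as does whether a smaller group than phenylsulfonyl on the chain carbon would behave like hydrogen. Nothing given here accounts for any of these steps.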